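This account rests on a few compounds, and the source may have more. Where it says the series, first, only, none or still open, it means among the compounds named here.

Measured compounds:
compound 1, `CN(C)c1ccc(C(=O)N2CCC(NS(=O)(=O)c3cc(S(=O)(=O)c4ccccc4)ccc3C(F)(F)F)CC2)cn1`: 70 nM
compound 2, `CC(C)(C)OC(=O)N1CC[C@@H](C(=O)N2CCC(NS(=O)(=O)c3cc(S(=O)(=O)c4ccccc4)ccc3C(F)(F)F)CC2)C1`: 80 nM

In an assay on U2OS cells for inhibition of secreted frizzled-related protein 1 (Homo sapiens), read by a luciferase reporter, with a stated time of 18 h (a higher number here means that more compound is needed for the effect, a lower number that less compound is needed), compound 2 gives 80 nM. For the measured compounds named here, its only neighbour on this set is compound 1, and the step of a 1.1-fold higher number from compound 1 to compound 2 (0.06 log units; within the scatter) tells that the two numbers cannot be told apart. That step exchanges the group on the carbonyl carbon of the shared core and leaves the rest untouched.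

Compound 3, `O=C([C@@H]1CCNC1)N1CCC(NS(=O)(=O)c2cc(S(=O)(=O)c3ccccc3)ccc2C(F)(F)F)CC1`, is reached from compound 2 by a different kind of change: hydrogen in place of tert-butoxycarbonyl on an amine nitrogen in a ring. The site is an amine nitrogen in a ring of a five-membered non-aromatic ring with 1 nitrogen, two ring bonds from the ring atom that bears a large group. Going by the values given here, no measured step touches this site, and the single step that exists, from one carbonyl substituent to another, stayed within the scatter. There is therefore nothing in the numbers to point in either direction, and the expectation is a step of a 1.3-fold higher number from compound 2 to compound 3 (0.10 log units; within the scatter) with wide uncertainty. For compound 3 in this assay the estimate is 100 nM, expected to fall between 25 nM and 400 nM.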

Compound 3, half-maximal effective concentration: 380 nM
Estimate against measurement, compound 3: 3.8-fold (0.58 log units) below; the measured number falls inside the stated range.
By their numbers in this assay, from the lowest: compounds 1 and 2 (each within the scatter of the next); then compound 3.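

Taking off the tert-butoxycarbonyl group from the amine nitrogen of the five-membered ring gives the first change here that clearly moves the number in this assay, with a 4.8-fold higher number from compound 2 to compound 3 (0.68 log units; beyond the scatter) standing beyond the scatter of repeated measurements. The comparison with the other carbonyl substituent points the same way, since a 5.4-fold higher number from compound 1 to compound 3 (0.73 log units; beyond the scatter) is also beyond the scatter, so the bare pyrrolidin-3-yl needs more compound than either 1-(tert-butoxycarbonyl)pyrrolidin-3-yl or 6-(dimethylamino)pyridin-3-yl, two groups whose numbers could not be told apart. Nothing measured on these compounds goes beyond these numbers to say why the hydrogen at this nitrogen fares differently from the larger groups.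

As far as these compounds go, whether a small group on the same nitrogen, such as a methyl or an acetyl, would give a number like that of compound 2 or like that of compound 3 remains open. From the compounds shown here alone, a methyl carbamate at that nitrogen would help separate the part played by the tert-butyl end of the group from that of its carbonyl, and that question also stays open.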